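A few compounds are considered here, and "the series" means these few. Any claim that something is new, unique, unknown or untested is made for them only; others in the source may bear on it.

Compounds measured in an ADME assay on BJ cells (Homo sapiens) for cytotoxicity, read by CellTiter-Glo and resazurin assay, with a stated time of 72 h (a higher number here means that more compound is needed for the effect, a lower number that less compound is needed), all at the limit of the assay:

Compound 1 `CC(C)N(Cc1cccc(OCCCCCC(=O)O)c1)C(=O)c1ccc(-c2ccoc2)cc1` gives > 26000 nM, a limit of the assay.
Compound 2 `CC(C)N(Cc1cccc(OCCCCCC(=O)O)c1)C(=O)c1ccc(-c2ccc3[nH]ccc3c2)cc1` gives > 26000 nM, a limit of the assay.
Compound 3 `CCOC(=O)CCCCCOc1cccc(CN(C(=O)c2ccc(-c3ccoc3)cc2)C(C)C)c1` gives > 26000 nM, a limit of the assay.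

Compound 3 therefore stands where the other two stand: on the limit, with no number of its own, and its position relative to compound 1 and compound 2 cannot be read. Compound 4 `CCOC(=O)CCCCCOc1cccc(CN(C(=O)c2ccc(-c3cccc(F)c3)cc2)C(C)C)c1` differs from compound 3 by 3-fluorophenyl in place of furan-3-yl on an aromatic carbon. Going by the values given here, two measured steps touch this change. The step that the two limits leave unreadable from compound 1 to compound 2 exchanges the same aromatic ring on the same aromatic carbon and is not readable in size. The step that the two limits leave unreadable from compound 1 to compound 3 is equally unreadable, since the limit of > 26000 nM in this assay, at which 3 of the 3 values shown sit, shows every value of the series resting on the limit. Among the compounds with values here, no step in this assay has yet been resolved, so the evidence gives no direction for the change into compound 4. The expectation for compound 4 is a further limit, with an estimated step that the limit leaves unreadable from compound 3 to compound 4 that is not beyond the scatter. Compound 4 is estimated at 30000 nM, within 13000 nM to 70000 nM, with the assay most likely reporting only a limit again.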

Compound 4, half-maximal effective concentration: > 26000 nM
Compound 4 was reported as a limit (the forecaster's own chance of this, stated with the estimate: 80%); the middle value lies beyond the limit too.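

No step can be read from compound 3 to compound 4, since both rest on the same limit: the limit of > 26000 nM in this assay, at which 4 of the 4 values shown sit.

The compounds shown leave open where any of them lies past that limit in this assay, and whether 3-fluorophenyl in place of furan-3-yl changes anything.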